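Ethyl in place of acetyl on a nitroxide chain

A few compounds are considered here, and "the series" means these few. Any claim that something is new, unique, unknown or untested is made for them only; others in the source may bear on it.

Measured compounds in a functional assay on HeLa cells (Homo sapiens) for cytotoxicity; on this read-out lower numbers stand for higher toxicity in this test and higher numbers for lower toxicity in this test:
- compound 1 `COC[C@H](/N=[N+](\[O-])CCCCCCC(C)=O)[C@H](C)O`: > 50 ug/mL.
- compound 2 `CCCCCC(O)/C=C/[N+]([O-])=N/[C@@H](COC)[C@H](C)O`: > 50 ug/mL.

The value of compound 1, > 50 ug/mL, is a limit of this assay rather than a number. The value of compound 2, > 50 ug/mL, is likewise only a limit. Among the measured compounds shown here, compound 1 therefore stands where every value shown stands, at the limit of > 50 ug/mL in this assay, at which 2 of the 2 values shown sit, and no step between measured compounds can be drawn from these two entries.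

Compound 3 `CCCCCCCC/[N+]([O-])=N/[C@@H](COC)[C@H](C)O` has not yet been measured in this assay. It differs from compound 1 in one place: ethyl in place of acetyl on a saturated chain carbon, six bonds along the chain from a double-bonded nitrogen. For the measured compounds named here, no measured pair tells how such a change moves this read-out. With both values shown sitting at the limit, the step from compound 1 to compound 3 is expected to be none beyond the scatter, as a step that the limit leaves unreadable from compound 1 to compound 3. Compound 3 is accordingly estimated at 60 ug/mL, within a range from 25 ug/mL to 200 ug/mL, most probably again reported only as a limit.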

Compound 3, half-maximal cytotoxic concentration: 30.5 ug/mL
Estimate against measurement, compound 3: 2.0-fold (0.29 log units) above; measured number inside the range.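

In this assay, compound 3 gives 30.5 ug/mL, the only number shown that is not a limit, so ethyl in place of acetyl on a saturated chain carbon, six bonds along the chain from a double-bonded nitrogen, yields a readable value on this core. The change gives an at least 1.6-fold lower number from compound 1 to compound 3 (0.21 log units; that floor lies within the scatter), which points towards higher toxicity in this test, although the floor alone does not clear the usual scatter. The true size of the step stays unknown because compound 1 is recorded only as a limit: the limit of > 50 ug/mL in this assay, at which 2 of the 3 values shown sit.

The compounds shown leave open how an amine, a carboxylic acid or a longer chain at this place would read in this assay. Among the compounds shown here, no step involving compound 2 can be read.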